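A few compounds are considered here, and "the series" means these few. Any claim that something is new, unique, unknown or untested is made for them only; others in the source may bear on it.

Measured compounds in this series:
- compound 1 `O=C(Nc1cccc(-n2cc(-c3ccncc3)c(-c3cc(O)cc(Cl)c3)n2)c1)Nc1ccc(Cl)c(C(F)(F)F)c1`: -72%
- compound 2 `COc1cc(Cl)cc(-c2nn(-c3cccc(NC(=O)Nc4ccc(Cl)c(C(F)(F)F)c4)c3)cc2-c2ccncc2)c1`: -58%
- compound 3 `COc1cc(Cl)cc(-c2nn(-c3cccc(NC(=O)Nc4cc(C(F)(F)F)cc(C(F)(F)F)c4)c3)cc2-c2ccncc2)c1`: -92%

In a functional assay on RXF 393 cells (Homo sapiens) for inhibition, read by sulforhodamine B assay, with a stated time of 48 h, tested at 100 uM (on this read-out lower numbers stand for a stronger effect and higher numbers for a weaker effect at the one concentration tested), compound 2 stands highest of the three numbers, the nearest being compound 1 and the furthest compound 3. Going by the values given here, the one single-site step known, a number 14 percentage points higher from compound 1 to compound 2 (beyond the scatter), concerns the oxygen on an aromatic ring and not the urea end. Compound 4 `COc1cc(Cl)cc(-c2nn(-c3cccc(NC(=O)c4cccc(C(F)(F)F)c4)c3)cc2-c2ccncc2)c1` differs from compound 2 at that urea end: 3-(trifluoromethyl)phenyl in place of (4-chloro-3-(trifluoromethyl)phenyl)amino on a carbonyl carbon. Among the compounds with values here, no measured step covers this kind of change, so nothing among the three compounds bears directly on it. With the donor and the chlorine gone, the number for compound 4 is expected to move higher, a step of a number 23 percentage points higher from compound 2 to compound 4 (beyond the scatter) beyond the scatter. The estimate for compound 4 is -35%, with a range from -70% to 5%.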

Compound 4, a percentage reported as activity, at one concentration (the size of the read-out at that concentration, not a potency): 19%
The estimate for compound 4 lay 54 percentage points below the measured number, outside the stated range (above it).
By their numbers in this assay, from the lowest: compound 3; then compound 1; then compound 2; then compound 4.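

In this assay, going by these compounds alone, the urea end is the more sensitive place so far: a number 77 percentage points higher from compound 2 to compound 4 (beyond the scatter), a larger step than a number 14 percentage points higher from compound 1 to compound 2 (beyond the scatter) at the oxygen on the aromatic ring. This single change removes both the amino nitrogen and the chlorine, so compound 4 cannot assign the step to either one. Nothing available bears on the cause of this step.

Still open, on these data alone, is how much of the step belongs to each loss. A urea carrying 3-(trifluoromethyl)phenyl alone, or a methylene in place of the amino nitrogen, would separate the two.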